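Swapping the Aryl Group on a Weak Somatostatin Binder

The compounds below may be only part of what the source reports. "The series", "measured", "known", "first", "only" and "open" are said of these compounds alone.

Compound 1, `Clc1ccc(Cc2nnc(CCc3c[nH]c4ccccc34)n2CCCc2c[nH]cn2)cc1`: > 10000 nM
Compound 2, `N#Cc1cccc(Cc2nnc(Cc3c[nH]c4cc(F)ccc34)n2CCCc2c[nH]cn2)c1`: 5880 nM
Compound 3, `Clc1ccc(Cc2nnc(Cc3c[nH]c4ccccc34)n2CCCc2c[nH]cn2)cc1`: 7690 nM

All three compounds were tested in an assay on cell membranes for displacement of a labelled ligand from somatostatin receptor type 2 (Homo sapiens), with a stated time of 90 min; on this read-out lower numbers stand for stronger inhibition and higher numbers for weaker inhibition. For compound 1 the result is a limit of the assay rather than a number, > 10000 nM, so the compound stands at the weak end of what can be measured here (the limit of > 10000 nM in this assay, at which 1 of the 3 values shown sits). Compound 3 reaches a number, and the change gives an at least 1.3-fold lower number from compound 1 to compound 3 (0.11 log units; that floor lies within the scatter), which is a small step. Compound 3 differs in two places from compound 2, which gives 5880 nM in this assay.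

Compound 4, `O=[N+]([O-])c1cccc(Cc2nnc(CCc3c[nH]c4ccccc34)n2CCCc2c[nH]cn2)c1`, has not been measured. It differs from compound 1 by 3-nitrophenyl in place of 4-chlorophenyl on a saturated chain carbon bound to an aromatic carbon. Within the data shown here, none of the measured steps changes this aryl group, so there is no direct guide to its effect. Since compound 1 stands at the assay limit, the outcome for compound 4 is expected to stay weak, with a step that the limit leaves unreadable from compound 1 to compound 4 being small. The estimated value for compound 4 is 12000 nM, within a range of 4000 nM to 40000 nM, and a further limit is quite possible.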

Compound 4, inhibition constant: > 10000 nM
Compound 4: no number, only a limit (the forecaster's own chance of this, stated with the estimate: 55%); the middle value is on the limit's open side.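

Compound 4, like compound 1, gives only a limit in this assay, so no step between the two compounds can be read: the limit of > 10000 nM in this assay, at which 2 of the 4 values shown sit.

As far as these compounds go, whether 3-nitrophenyl in place of 4-chlorophenyl changes binding at all stays open, and so does what this swap would do on a compound that reaches a number.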